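This account rests on a few compounds, and the source may have more. Where it says the series, first, only, none or still open, it means among the compounds named here.

Compound 1 `COc1ccc(-c2cccc(NC(=O)CCc3cccc4c3B(O)OC4)c2)cc1` gives 1400 nM in the assay described below
Compound 2 `O=C(CCc1cccc2c1B(O)OC2)Nc1cccc(-c2ccc(OC(F)(F)F)cc2)c1` gives 25000 nM in the same assay

For the measured compounds named here, in an ADME assay on WI-38 cells (Homo sapiens) for cytotoxicity, read by MTT assay, with a stated time of 72 h (on this read-out lower numbers stand for stronger inhibition and higher numbers for weaker inhibition), compound 2 reads 25000 nM as the higher of the two numbers so far, making it the weaker inhibitor of the pair. Compound 3 `O=C(CCc1cccc2c1B(O)OC2)Nc1cccc(-c2ccc(C(F)(F)F)cc2)c1` has trifluoromethyl in place of trifluoromethoxy on an aromatic carbon and keeps the rest of compound 2 unchanged. One measured change bears on this, namely an 18-fold higher number from compound 1 to compound 2 (1.25 log units; beyond the scatter) as a large step. That step replaced methyl with trifluoromethyl on the oxygen, whereas here the oxygen itself leaves and the fluorinated carbon stays. It is therefore only a loose guide, and no step beyond the scatter is expected in this assay here. The estimated change is a 1.7-fold lower number from compound 2 to compound 3 (0.22 log units; within the scatter) and would be small. For compound 3 the expected value is 15000 nM with an estimated range from 4000 nM to 50000 nM around it.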

Compound 3, half-maximal inhibitory concentration: 26000 nM
Estimate against measurement, compound 3: 1.7-fold (0.24 log units) below; the measured number falls inside the stated range.
By their numbers in this assay, from the lowest: compound 1; then compounds 2 and 3 (each within the scatter of the next).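

Trading trifluoromethoxy for trifluoromethyl at this position gives a 1.0-fold higher number from compound 2 to compound 3 (0.02 log units; within the scatter) in this assay, so the oxygen joining the group to the ring makes no readable difference here. The earlier step compared only methoxy with trifluoromethoxy, where the oxygen stayed in place, whereas a 19-fold higher number from compound 1 to compound 3 (1.27 log units; beyond the scatter) shows that methoxy also stands apart from a fluorinated group that has no such oxygen. Nothing shown explains why the two fluorinated groups read alike or why methoxy differs from both.

The compounds shown leave open how a group of another kind, such as an amine or a carboxylic acid, would read at this position. They also leave open whether a plain methyl or a longer chain of carbon atoms would fall nearer to methoxy or to the two fluorinated groups.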